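Losing the (methylsulfanyl)methyl group from compound 2

The compounds below may be only part of what the source reports. "The series", "measured", "known", "first", "only" and "open" are said of these compounds alone.

- compound 1 `COC[C@H](NC(=O)[C@H](CSC)NC(=O)c1cc(Cl)ccc1Cl)C(=O)N[C@@H](CC(C)C)C(=O)[C@@]1(C)CO1`: < 0.0834 h
- compound 2 `COC[C@H](NC(=O)c1cc(C)on1)C(=O)N[C@@H](CSC)C(=O)N[C@@H](CC(C)C)C(=O)[C@@]1(C)CO1`: 0.518 h
- compound 3 `CSC[C@H](NC(=O)c1cc(C)on1)C(=O)N[C@@H](CSC)C(=O)N[C@@H](CC(C)C)C(=O)[C@@]1(C)CO1`: 0.132 h

In an ADME assay on microsomes from liver (Rattus norvegicus) for metabolic stability (on this read-out lower numbers stand for a shorter-lived compound and higher numbers for a longer-lived compound), compound 1 gives < 0.0834 h, which is a limit of the assay and not a number. Of the two true numbers, the higher belongs to compound 2, at 0.518 h. Compound 4 `COC[C@H](NC(=O)c1cc(C)on1)C(=O)NCC(=O)N[C@@H](CC(C)C)C(=O)[C@@]1(C)CO1` differs from it as follows: hydrogen in place of (methylsulfanyl)methyl on a saturated chain carbon bound to an amide-type nitrogen and a carbonyl carbon. Hydrogen replaces (methylsulfanyl)methyl on a saturated chain carbon bound to an amide-type nitrogen and a carbonyl carbon. Going by the values given here, only one measured step bears on this, a modest one at a different place: methylsulfanyl in place of methoxy gives a 3.9-fold lower number from compound 2 to compound 3 (0.59 log units; beyond the scatter). On that basis, a small rise within the scatter is expected in this assay, a 1.3-fold higher number from compound 2 to compound 4 (0.10 log units; within the scatter). For compound 4 the estimate is 0.65 h, with an expected range of 0.25 h to 1.6 h.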

Compound 4, half-life: 1.86 h
The estimate for compound 4 lay 2.9-fold (0.46 log units) below the measured number, outside the stated range (above it).
By their numbers in this assay, from the lowest: compound 3; then compound 2; then compound 4. At a limit, below all of these: compound 1.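

In this assay, this saturated chain carbon proves sensitive to what it carries: hydrogen in place of (methylsulfanyl)methyl gives a 3.6-fold higher number from compound 2 to compound 4 (0.56 log units; beyond the scatter). Going by these compounds alone, the earlier compounds offered only a step at a different place, a 3.9-fold lower number from compound 2 to compound 3 (0.59 log units; beyond the scatter), so this is the first reading at this position, and it runs the opposite way. Nothing in the data shown accounts for the rise. The compounds shown leave open whether the longer life comes from losing the sulfur or from losing the whole chain. A methyl group on this carbon would separate the two.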